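The source may hold more compounds than are shown below. What is called first, only, known or untested is meant among the compounds shown, and "the series" means these compounds.

Compound 1 `CCCCNc1cncc(C(=O)NCc2ccccc2)n1`: > 100000 nM
Compound 2 `CCCCCCCCNc1nccnc1C(=O)NCc1ccccc1`: > 100000 nM

In an ADME assay on HeLa cells (Homo sapiens) for cytotoxicity, read by microscopy, with a stated time of 6 days (on this read-out higher numbers stand for lower toxicity in this test and lower numbers for higher toxicity in this test), compound 1 gives > 100000 nM, which is a limit of the assay and not a number. Compound 2 likewise sits at a limit, > 100000 nM in this assay. Going by the values given here, compound 1 thus stands with its only neighbour at the boundary of what the test reports, as the limit of > 100000 nM in this assay, at which 2 of the 2 values shown sit, shows. Compound 3 `CCCCCCCNc1cncc(C(=O)NCc2ccccc2)n1` differs from compound 1 by propyl in place of hydrogen on a saturated chain carbon, four bonds along the chain from a nitrogen on an aromatic ring. Among the compounds with values here, no measured step exists to lean on; the step of a number no higher from compound 1 to compound 3 (the limit leaves the size open) in this assay is expected to be none beyond the scatter, because the limit of > 100000 nM in this assay, at which 2 of the 2 values shown sit, places both measured readings at the limit. Compound 3 is therefore expected near 100000 nM, within 30000 nM to 300000 nM.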

Compound 3, minimum cytotoxic concentration: > 100000 nM
Compound 3 ended at the assay's limit; the forecaster's own chance of this, stated with the estimate: 80%; the middle value lies on the limit itself.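

No step can be read from compound 1 to compound 3, as both readings are limits of the assay and not numbers: the limit of > 100000 nM in this assay, at which 3 of the 3 values shown sit. The compounds shown leave open how far beyond that limit each lies in this assay.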